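The source may hold more compounds than are shown below. What is called first, only, known or untested is meant among the compounds shown, and "the series" means these compounds.

Compound 2 `O[C@H]1CCC[C@@H]1N1CCN(CCCc2ccccc2Br)CC1` and compound 1 `O[C@H]1CCCC[C@@H]1N1CCN(CCCc2cccc(Br)c2)CC1` were both tested in an assay on membranes from cerebrum (strain Sprague-Dawley) for displacement of a labelled ligand from Sigma non-opioid intracellular receptor 1 (Rattus norvegicus), read by scintillation counting, with a stated time of 90 min; a higher number here means a weaker inhibitor, a lower number a stronger inhibitor. Compound 1 gives 7.7 nM, and compound 2 gives 37.1 nM, the higher of the two numbers, a gap beyond the scatter. Compound 3 `O[C@H]1CCC[C@@H]1N1CCN(CCCc2cccc(Br)c2)CC1` shares the core of compound 2 and differs from it in one place: 3-bromophenyl in place of 2-bromophenyl on a saturated chain carbon, three bonds along the chain from an amine nitrogen in a ring. Among the compounds with values here, no measured pair shows this change alone. Since compound 1 also carries a 3-bromophenyl and gives 7.7 nM, the step of a 3.1-fold lower number from compound 2 to compound 3 (0.49 log units; beyond the scatter) is expected to lower the number. Compound 3 is estimated at 12 nM, within a range from 4 nM to 35 nM.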

Compound 3, inhibition constant: 4.8 nM
Beside the measured number, compound 3's estimate is 2.5-fold (0.40 log units) above it; low and high end bracket the measured number.
By their numbers in this assay, from the lowest: compounds 3 and 1 (each within the scatter of the next); then compound 2.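

In this assay, 3-bromophenyl in place of 2-bromophenyl gives a 7.7-fold lower number from compound 2 to compound 3 (0.89 log units; beyond the scatter) with nothing else changed, the first direct measure of this swap. 2-hydroxycyclopentyl in place of 2-hydroxycyclohexyl gives a 1.6-fold lower number from compound 1 to compound 3 (0.21 log units; within the scatter) and so makes no clear difference when 3-bromophenyl is present. Nothing measured here explains the effect of the bromophenyl swap.

The compounds shown leave open how 4-bromophenyl or 3-chlorophenyl would compare with 3-bromophenyl at this place. They also leave open whether the swap would give a similar step with 2-hydroxycyclohexyl on the amine nitrogen.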